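From (1-phenylethyl)amino to piperidin-1-yl, and back

The source may report more compounds than this note shows. Statements on the series, on what has been measured and on what is new or still open speak of the compounds shown alone.

In a functional assay on MCF7 cells (Homo sapiens) for antiproliferative activity, read by MTT assay, with a stated time of 24 h (on this read-out higher numbers stand for weaker inhibition and lower numbers for stronger inhibition), compound 1 `CCCCc1oc2ccccc2c1C(=O)c1ccc(OCC(=O)NCc2ccccc2)cc1` gives 19600 nM, compound 2 `CCCCc1oc2ccccc2c1C(=O)c1ccc(OCC(=O)N[C@@H](C)c2ccccc2)cc1` gives 17900 nM, and compound 3 `CCCCc1oc2ccccc2c1C(=O)c1ccc(OCCCC(=O)N2CCCCC2)cc1` gives 33000 nM. These three values lie within the usual scatter of one another, so compound 3 cannot be separated from the other two. Compound 4 `CCCCc1oc2ccccc2c1C(=O)c1ccc(OCCCC(=O)N[C@@H](C)c2ccccc2)cc1` differs from compound 3 only in the group on a carbonyl carbon: (1-phenylethyl)amino in place of piperidin-1-yl on a carbonyl carbon. The closest evidence is a 1.8-fold higher number from compound 2 to compound 3 (0.27 log units; within the scatter), where 2-((piperidin-1-yl)carbonyl)ethyl takes the place of (1-phenylethyl)carbamoyl. A similar exchange starting from benzylcarbamoyl gives a 1.7-fold higher number from compound 1 to compound 3 (0.23 log units; within the scatter). Neither change isolates the swap made here, and both stay within the scatter. No step beyond the scatter is therefore expected in this assay, only a slight lean towards a lower number. The expected change is a 1.4-fold lower number from compound 3 to compound 4 (0.16 log units; within the scatter). For compound 4 the estimated value is 23000 nM, with an expected range from 12000 nM to 40000 nM.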

Compound 4, half-maximal inhibitory concentration: > 50000 nM
Compound 4: a limit, no number; the forecaster's own chance of this, stated with the estimate: 3%; middle value at least 2.1-fold (0.33 log units) from the limit.
By their numbers in this assay, from the lowest: compounds 2, 1 and 3 (each within the scatter of the next). At a limit, above all of these: compound 4.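

Compound 4 gives a limit and not a number in this assay, and it is the only compound shown to do so: the limit of > 50000 nM in this assay, at which 1 of the 4 values shown sits.

Going by these compounds, this means that the change on the carbonyl carbon can be read only as a floor, an at least 1.5-fold higher number from compound 3 to compound 4 (0.18 log units; that floor lies within the scatter), and its true size remains unknown. Compound 2 carries the same (1-phenylethyl)amino group on a carbonyl carbon with a different chain and gives 17900 nM. The limit seen for compound 4 is thus not shared by every compound that holds this group.

On these data alone, how a benzylamino or a dimethylamino group would behave on the chain of compound 3 and compound 4 remains open. So does the outcome for a carboxylic acid at that carbonyl carbon, or for the opposite mirror-image form of the (1-phenylethyl)amino group.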